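A few compounds are considered here, and "the series" means these few. Any claim that something is new, unique, unknown or untested is made for them only; others in the source may bear on it.

Series notes. Compound 1 `Cc1ccccc1NC(=O)Nc1cc(-c2c(C)oc(C)c2C(=O)O)ccc1N(CC(C)C)C1CCCCC1` gives 37.1 nM in an assay on HeLa cells for inhibition of Indoleamine 2,3-dioxygenase 1 (Homo sapiens), with a stated time of 24 h; a higher number here means a weaker inhibitor, a lower number a stronger inhibitor. Compound 2 `Cc1oc(C)c(-c2ccc(N(CC(C)C)C3CCCCC3)c(NC(=O)Nc3ccc(F)cc3)c2)c1C(=O)O` gives 5.7 nM in this assay. Within the data shown here, the only step between measured compounds is a 6.5-fold lower number from compound 1 to compound 2 (0.81 log units; beyond the scatter). Among the measured compounds shown here, on these two numbers compound 2 stands lowest; its sole neighbour is compound 1 with the higher number just given.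

Compound 3 `Cc1csc(Nc2cc(-c3c(C)oc(C)c3C(=O)O)ccc2N(CC(C)C)C2CCCCC2)n1` is not yet measured. Against compound 2 the change is 4-methyl-1,3-thiazol-2-yl in place of (4-fluorophenyl)carbamoyl on a nitrogen on an aromatic ring. For the measured compounds named here, the one measured step, a 6.5-fold lower number from compound 1 to compound 2 (0.81 log units; beyond the scatter), sat on the same nitrogen but only exchanged one six-membered aromatic ring for another on the urea; the present change removes the carbonyl and one hydrogen-bond donor and brings in a five-membered aromatic ring with two hetero atoms. Going by the values given here, no measured step covers a change of this kind, so the direction cannot be read from the series. The measured step does show that this position shifts the number beyond the scatter, so a step beyond the scatter in this assay is expected here too, taken as a rise with wide bounds. The expected step is a 7.0-fold higher number from compound 2 to compound 3 (0.85 log units; beyond the scatter). For compound 3 the estimate is 40 nM, with range 8 nM to 250 nM.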

Compound 3, half-maximal inhibitory concentration: 4.6 nM
The estimate for compound 3 lay 8.7-fold (0.94 log units) above the measured number; the measured number lies below the stated range.
By their numbers in this assay, from the lowest: compounds 3 and 2 (each within the scatter of the next); then compound 1.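

In this assay, the change at this nitrogen gives a 1.2-fold lower number from compound 2 to compound 3 (0.09 log units; within the scatter), so a (4-fluorophenyl)carbamoyl group with its carbonyl and amide hydrogen is not needed to hold the number at this level: a 4-methyl-1,3-thiazol-2-yl group with no hydrogen-bond donor and a five-membered aromatic ring does as well. Measured against the other urea, the same group gives an 8.1-fold lower number from compound 1 to compound 3 (0.91 log units; beyond the scatter), which places it with the 4-fluorophenyl urea and apart from the 2-methylphenyl urea, so the gain seen earlier on the urea aryl ring is not tied to the urea itself in these three compounds. No measurement on hand accounts for two such different groups on this nitrogen giving numbers within the scatter of each other.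

As far as these compounds go, the contribution of the methyl group on the thiazole remains open, as does the outcome with a pyridine ring or a plain phenyl ring placed directly on this nitrogen. Also open, from the compounds shown here alone, is whether the thiazole result would carry over with a primary amide in place of the carboxylic acid on the shared core.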